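A few compounds are considered here, and "the series" means these few. Any claim that something is new, unique, unknown or untested is made for them only; others in the source may bear on it.

Compound 1 `O=C(O)CCC(=O)OCCCCCCSc1ccc([N+](=O)[O-])c2nonc12` gives 530 nM in an assay on isolated protein for inhibition of glutathione S-transferase P (Homo sapiens), with a stated time of 10 min; a lower number here means a stronger inhibitor, a higher number a weaker inhibitor. Compound 2 `O=C(CCC(=O)OCCCCCCSc1ccc([N+](=O)[O-])c2nonc12)Nc1ccccc1` gives 10200 nM in this assay, the higher of the two numbers, after the large step of a 19-fold higher number from compound 1 to compound 2 (1.28 log units; beyond the scatter). Compound 3 `O=C(CCC(=O)OCCCCCCSc1ccc([N+](=O)[O-])c2nonc12)Nc1ccccc1F` differs from compound 2 by fluoro in place of hydrogen on an aromatic carbon. Among the compounds with values here, no measured step touches that ring: the only known step, a 19-fold higher number from compound 1 to compound 2 (1.28 log units; beyond the scatter), concerns the carbonyl substituent, not the ring itself, so it does not bear on this change. Compound 3 is therefore expected to show a step of a 1.0-fold lower number from compound 2 to compound 3 (0.01 log units; within the scatter), none beyond the scatter. Compound 3 is estimated at 10000 nM, between 4000 nM and 25000 nM.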

Compound 3, half-maximal inhibitory concentration: 9890 nM
The estimate for compound 3 lay 1.0-fold (0.00 log units) above the measured number; low and high end bracket the measured number.
By their numbers in this assay, from the lowest: compound 1; then compounds 3 and 2 (each within the scatter of the next).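

Fluoro in place of hydrogen, ortho to a large group on the phenyl ring, gives a 1.0-fold lower number from compound 2 to compound 3 (0.01 log units; within the scatter) and so leaves the number within the scatter of the unsubstituted anilide. With (2-fluorophenyl)amino in place of hydroxy on the carbonyl carbon, the large step seen with anilino persists as a 19-fold higher number from compound 1 to compound 3 (1.27 log units; beyond the scatter) and is not recovered by this fluoro. No supporting evidence bears on why this is so. On these data alone, whether a methoxy group or an amine on this ring would move the number stays open, as does the effect of a shorter or longer chain.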